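The source may report more compounds than this note shows. Statements on the series, on what has been measured and on what is new or still open speak of the compounds shown alone.

Measured compounds:
compound 1 `Cc1cc(-c2cnc(NCc3c(F)ccc4c3CCO4)c3cn[nH]c(=O)c23)n(C)n1` — 1000 nM
compound 2 `O=C(Nc1ccccc1)c1cnc(NCc2c(F)ccc3c2CCO3)n2cnnc12` — < 1000 nM
compound 3 `CN(c1cccnc1)c1cnc(NCc2c(F)ccc3c2CCO3)n2cnnc12` — 47000 nM

In a physicochemical assay for solubility, read by LC-MS, in phosphate buffer, with a stated time of 24 h, at pH 7.4 (a higher number here means a more soluble compound, a lower number a less soluble compound), compound 1 gives 1000 nM, the lowest of the two numbers reported. Compound 3 gives 47000 nM in this assay, a higher number than compound 1. For compound 2 the result in this assay is a limit, < 1000 nM, and not a number; it sits at the limit of < 1000 nM in this assay, at which 1 of the 3 values shown sits.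

Among the compounds with values here, the only step between two measured compounds is an at least 47-fold higher number from compound 2 to compound 3 (1.67 log units; beyond the scatter), which replaces methyl(pyridin-3-yl)amino with phenylcarbamoyl on a core that compound 1 does not share, so it bears only loosely on the change now followed.

Compound 4 `Cc1nc(CO)ccc1-c1cnc(NCc2c(F)ccc3c2CCO3)c2cn[nH]c(=O)c12` is not yet measured. It differs from compound 1 by 6-(hydroxymethyl)-2-methylpyridin-3-yl in place of 1,3-dimethyl-1H-pyrazol-5-yl on an aromatic carbon. Within the data shown here, no measured step covers this exchange on the core of compound 1, so the expectation rests on compound 1 alone, with 1000 nM as the anchor and only a modest shift foreseen. Compound 4 is therefore expected to give 2500 nM in this assay, between 800 nM and 8000 nM, a step of a 2.5-fold higher number from compound 1 to compound 4 (0.40 log units; beyond the scatter) that is estimated to stay close to the scatter.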

Compound 4, solubility: 3000 nM
The estimate for compound 4 lay 1.2-fold (0.08 log units) below the measured number; low and high end bracket the measured number.
By their numbers in this assay, from the lowest: compound 1; then compound 4; then compound 3.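

Within the data shown here, on the core of compound 1, this aromatic carbon, para to a large group, now has a measured exchange, whereas the only earlier step lay on a different core. In this assay, 6-(hydroxymethyl)-2-methylpyridin-3-yl in place of 1,3-dimethyl-1H-pyrazol-5-yl gives a 3.0-fold higher number from compound 1 to compound 4 (0.48 log units; beyond the scatter) and so shows that this position responds to the exchange, though far less than the large step seen on the other core. Among these compounds, the exchange alters several things at once, since a five-membered aromatic ring gives way to a six-membered one and a hydrogen-bond donor enters, and the single step cannot separate these features.

Going by these compounds, whether an aminomethyl group or a carboxylic acid in place of the hydroxymethyl would move the number further remains open. Nothing shown here gives a cause for the step.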